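Chloro on the furan ring of the aryl-methyl amide series

The compounds below may be only part of what the source reports. "The series", "measured", "known", "first", "only" and "open" are said of these compounds alone.

In a functional assay on SMA cells (Homo sapiens) for inhibition, read by MTT assay, with a stated time of 72 h (on this read-out higher numbers stand for weaker inhibition of growth and lower numbers for stronger inhibition of growth), compound 1 `N#C/C(=C\c1c(F)c(F)c(F)c(F)c1F)C(=O)c1c[nH]c2ccccc12` gives 20000 nM. For compound 2 `COc1ccc(CNC(=O)/C(C#N)=C/c2ccc[nH]2)cc1` this assay reports only a limit, > 50000 nM (the limit of > 50000 nM in this assay, at which 1 of the 3 values shown sits). Compound 3 `COc1ccc(CNC(=O)/C(C#N)=C/c2ccco2)cc1` gives 33000 nM in this assay; the gap to compound 1 lies within the scatter, so no order between the two is read. For the measured compounds named here, the one measured step is an at least 1.5-fold lower number from compound 2 to compound 3 (0.18 log units; that floor lies within the scatter). Compound 4 `COc1ccc(CNC(=O)/C(C#N)=C/c2ccc(Cl)o2)cc1` differs from compound 3 by chloro in place of hydrogen on an aromatic carbon. Going by the values given here, no measured step covers a halogen on this ring, and the ring swap itself stayed within the scatter, so no step beyond the scatter is expected in this assay. Compound 4 is therefore estimated at 25000 nM (range 8000 nM to 60000 nM), an expected step of a 1.3-fold lower number from compound 3 to compound 4 (0.12 log units; within the scatter).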

Compound 4, concentration for 50% growth inhibition: 14000 nM
For compound 4 the middle estimate is 1.8-fold (0.25 log units) above the measured one; the range from low to high includes it.
By their numbers in this assay, from the lowest: compounds 4, 1 and 3 (each within the scatter of the next, the first and the last beyond it). At a limit, above all of these: compound 2.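

In this assay, chloro on the aromatic carbon next to the ring oxygen gives a step beyond the scatter (a 2.4-fold lower number from compound 3 to compound 4 (0.37 log units; beyond the scatter)), which the swap of 1H-pyrrol-2-yl for furan-2-yl alone did not show. Together, the ring swap and the chloro give a step also beyond the scatter (an at least 3.5-fold lower number from compound 2 to compound 4 (0.55 log units; beyond the scatter)). That step is only a floor, and compound 2 stands at a limit: the limit of > 50000 nM in this assay, at which 1 of the 4 values shown sits.

Open, from the compounds shown here alone, is whether bromo, fluoro or methyl on the same carbon would move the number as chloro does. Also open, going by these compounds, is whether chloro on the 1H-pyrrol-2-yl ring would do the same.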